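Variation of the alkyl group on the ring nitrogen

A few compounds are considered here, and "the series" means these few. Any claim that something is new, unique, unknown or untested is made for them only; others in the source may bear on it.

Measured so far in an assay on isolated protein for agonist activity at Bile acid receptor (Homo sapiens), read by TR-FRET; on this read-out higher numbers stand for an effect only at larger amounts of compound and lower numbers for an effect already at smaller amounts:
compound 1 `CCC(CC)n1c(-c2ccc(OCc3c(-c4c(Cl)cccc4Cl)noc3C(C)C)cc2)nc2ccc(C(=O)O)cc21` gives 26.5 nM
compound 2 `CCCC(CCC)n1c(-c2ccc(OCc3c(-c4c(Cl)cccc4Cl)noc3C(C)C)cc2)nc2ccc(C(=O)O)cc21` gives 30.3 nM

Compound 2 stands beside compound 1 on these two numbers: the step of a 1.1-fold higher number from compound 1 to compound 2 (0.06 log units; within the scatter) is within the scatter, so the two cannot be told apart in this assay. Among the measured compounds shown here, the only change between them is 1-propylbutyl in place of pentan-3-yl on the aromatic nitrogen, and it left the read-out unchanged beyond the noise.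

Compound 3 `CC(C)c1onc(-c2c(Cl)cccc2Cl)c1COc1ccc(-c2nc3ccc(C(=O)O)cc3n2CC2CCCCC2)cc1` is the next member and differs from compound 2 by cyclohexylmethyl in place of 1-propylbutyl on an aromatic nitrogen. For the measured compounds named here, the one measured step that bears on this change is that from compound 1 to compound 2, an exchange of one alkyl group for another at the same aromatic nitrogen, and it was within the scatter. Going by the values given here, on that basis no step beyond the scatter is expected for compound 3 in this assay, although the ring in cyclohexylmethyl has no precedent here and widens the range. The estimate for compound 3 is 30 nM, in the range 12 nM to 75 nM. This estimate means a step of a 1.0-fold lower number from compound 2 to compound 3 (0.00 log units; within the scatter), expected to fall within the scatter.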

Compound 3, half-maximal effective concentration: 19.9 nM
For compound 3 the middle estimate is 1.5-fold (0.18 log units) above the measured one, and the stated range covers the measured number.
By their numbers in this assay, from the lowest: compounds 3, 1 and 2 (each within the scatter of the next).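

In this assay, among the compounds shown here, compound 3 brings a ring into the group on the aromatic nitrogen for the first time. Cyclohexylmethyl matches 1-propylbutyl in its count of 7 heavy atoms, all carbon, but adds one six-membered non-aromatic ring, and the result is a 1.5-fold lower number from compound 2 to compound 3 (0.18 log units; within the scatter); against pentan-3-yl the result is a 1.3-fold lower number from compound 1 to compound 3 (0.12 log units; within the scatter). The read-out therefore does not separate these three alkyl groups, so among the listed compounds, a ring in the group at this position leaves the number indistinguishable from those of the two open-chain groups, and no measurement available here bears on why these groups read alike.

The compounds shown span only groups of carbon and hydrogen on this nitrogen, so it remains open whether a much shorter group such as methyl, an aromatic group such as benzyl, or a chain carrying an amine or a hydroxyl would stay in the same range. Going by these compounds, it also remains open whether the indifference seen with cyclohexylmethyl extends to smaller rings such as cyclopropylmethyl or to a ring bound directly to the nitrogen, as in cyclohexyl.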